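Pyrazoline series: bromo substitution on the phenyl of compound 1

A few compounds are considered here, and "the series" means these few. Any claim that something is new, unique, unknown or untested is made for them only; others in the source may bear on it.

Measured so far:
- compound 1 `CC(=O)N1N=C(c2ccccc2)CC1c1cccc(Cl)c1Cl`: 42900 nM
- compound 2 `COc1cc(C2CC(c3ccc(Br)cc3)=NN2C(C)=O)cc(OC)c1OC`: 3130 nM

In a functional assay on IMR-32 cells (Homo sapiens) for cytotoxicity, read by sulforhodamine B assay, with a stated time of 48 h (on this read-out higher numbers stand for weaker inhibition and lower numbers for stronger inhibition), compound 1 gives 42900 nM, the highest of the two numbers recorded. Its nearest neighbour, compound 2, gives 3130 nM, a gap that lies beyond the scatter. Compound 2 differs from compound 1 in two places at once, so nothing can be said about which of those two changes carries the difference.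

Compound 3 `CC(=O)N1N=C(c2ccc(Br)cc2)CC1c1cccc(Cl)c1Cl` is not yet measured in this assay. It differs from compound 1 by bromo in place of hydrogen on an aromatic carbon, a bromo in place of hydrogen on an aromatic carbon of a six-membered aromatic ring of carbon only. Compound 2 also carries a bromo on its corresponding ring and gives 3130 nM, but its second point of difference leaves that observation inconclusive.

The expectation for the step from compound 1 to compound 3 is therefore a modest move toward a lower number, a 2.1-fold lower number from compound 1 to compound 3 (0.33 log units; beyond the scatter), not clearly beyond the scatter. Compound 3 is estimated at 20000 nM, with a range from 6000 nM to 60000 nM.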

Compound 3, half-maximal inhibitory concentration: 45700 nM
Beside the measured number, compound 3's estimate is 2.3-fold (0.36 log units) below it; low and high end bracket the measured number.
By their numbers in this assay, from the lowest: compound 2; then compounds 1 and 3 (each within the scatter of the next).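

On the core of compound 1, the change from phenyl to 4-bromophenyl gives a 1.1-fold higher number from compound 1 to compound 3 (0.03 log units; within the scatter) in this assay, so a bromo on this aromatic carbon, para to a large group, leaves the read-out where it was. Compound 3 also separates the two changes that were tangled in compound 2: both compounds carry the 4-bromophenyl and differ only on the other aromatic ring, with compound 2 at 3130 nM and compound 3 at 45700 nM in this assay on the printed values. The lower number of compound 2 therefore does not follow from the bromo alone in this set, and it goes with the substituents on the other ring, the three methoxy groups of compound 2 in place of the two chloro groups of compounds 1 and 3.

No measurement in hand explains why the bromo makes so little difference here. Still open is whether this position would respond to a different kind of group, such as an amine or a carboxylic acid in place of the bromo, and whether the bromo is equally silent on the core of compound 2, for which no phenyl partner appears among the compounds shown.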